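The compounds below may be only part of what the source reports. "The series", "measured", "known", "first", "only" and "open" are said of these compounds alone.

In an ADME assay on HEp-2 cells (Homo sapiens) for cytotoxicity, read by MTT assay, with a stated time of 60 h (a higher number here means that more compound is tolerated, a lower number that less compound is tolerated), compound 1 `Cc1c(Br)cc2nc3n(c2c1Br)[C@H]1OC[C@@H](OS(C)(=O)=O)[C@H]1OC3` gives 23700 nM. Two other compounds have been measured in the same test. Compound 2 `O[C@@H]1CO[C@H]2[C@@H]1OCc1nc3cc(Br)c(Br)cc3n12` gives 181000 nM, and compound 3 `COc1ccc2c(nc3n2[C@H]2OC[C@@H](O)[C@H]2OC3)c1N` gives 109000 nM. These two values lie within the usual scatter of each other, whereas compound 1 has the lowest number of the three, clearly beyond that scatter. Compounds 2 and 3 differ from compound 1 in more than one place, so neither comparison isolates the effect of a single group.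

The next compound to be tested is compound 4 `Cc1c(Br)cc2nc3n(c2c1Br)[C@H]1OC[C@@H](OCc2ccccc2)[C@H]1OC3`. It keeps the core of compound 1 and changes one group, with benzyl in place of methylsulfonyl on an oxygen on a saturated carbon. For the measured compounds named here, no measured pair shows what this exchange does in this assay, so the only firm anchor is compound 1 at 23700 nM. The expectation therefore stays close to that value, leaning only slightly towards a higher number, and no shift beyond the scatter is predicted. The estimated step is a 1.3-fold higher number from compound 1 to compound 4 (0.10 log units; within the scatter). With so little evidence, the range is kept wide. For compound 4 the estimated value is 30000 nM, with an expected range from 10000 nM to 100000 nM.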

Compound 4, half-maximal cytotoxic concentration: 115000 nM
For compound 4 the middle estimate is 3.8-fold (0.58 log units) below the measured one; measured number outside the range, above it.
By their numbers in this assay, from the lowest: compound 1; then compounds 3, 4 and 2 (each within the scatter of the next).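

In this assay, for the compounds shown here, the exchange of methylsulfonyl for benzyl on an oxygen on a saturated carbon gives a 4.9-fold higher number from compound 1 to compound 4 (0.69 log units; beyond the scatter) and is the first change at a single place that can be read, showing that this position can shift the number while the core stays the same. The low number of compound 1 is therefore not set by the core alone, since the group on this oxygen also counts. Several counted features change together in this one exchange, with a ring-free group bearing hydrogen-bond acceptors leaving and a larger group with a six-membered aromatic ring and no such acceptors entering, and nothing measured explains the step.

On these data alone, it remains open whether the step comes from losing methylsulfonyl, from gaining benzyl, or from both. As far as these compounds go, a methyl or an acetyl group on the same oxygen would help to separate these readings, and whether the step holds on a different core also remains unknown.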